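Replacing the Amide Group of Compound 2

The compounds below may be only part of what the source reports. "The series", "measured", "known", "first", "only" and "open" are said of these compounds alone.

Measured in an in vitro ADME assay on microsomes from liver (Homo sapiens) for metabolic stability, tested at 1 uM (a lower number here means slower removal, a higher number faster removal of the compound), compound 2 `CNC(=O)c1cc(N)c(Nc2ccc(C#N)cc2)cc1Oc1c(C)cc(CCC#N)cc1C` gives 120 mL.min-1.g-1 and sits within the scatter of compound 1 `Cc1cc(/C=C/C#N)cc(C)c1Oc1cc(Nc2ccc(C#N)cc2)c(N)cc1C(N)=O` at 200 mL.min-1.g-1 while compound 3 `Cc1cc(CCC#N)cc(C)c1Oc1cc(Nc2ccc(C#N)cc2)c(N)cc1CO` gives 330 mL.min-1.g-1 on the same scale. Compound 4 `COC(=O)c1cc(N)c(Nc2ccc(C#N)cc2)cc1Oc1c(C)cc(CCC#N)cc1C` differs from compound 2 by methoxy in place of methylamino on a carbonyl carbon so methylcarbamoyl becomes methoxycarbonyl. For the measured compounds named here, the only measured step at this group, hydroxymethyl in place of methylcarbamoyl, is a 2.8-fold higher number from compound 2 to compound 3 (0.44 log units; beyond the scatter) and it is a different replacement, so it guides only roughly. A similar modest rise is therefore expected, an estimated 2.1-fold higher number from compound 2 to compound 4 (0.32 log units; beyond the scatter) in this assay terms. Compound 4 is estimated at 250 mL.min-1.g-1 with a range from 120 mL.min-1.g-1 to 500 mL.min-1.g-1 as the likely span.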

Compound 4, intrinsic clearance in microsomes: 40 mL.min-1.g-1
The estimate for compound 4 lay 6.3-fold (0.80 log units) above the measured number, outside the stated range (below it).
By their numbers in this assay, from the lowest: compound 4; then compounds 2, 1 and 3 (each within the scatter of the next, the first and the last beyond it).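

In this assay, the earlier step showed only a rise at this group, whereas methoxy in place of methylamino on a carbonyl carbon gives a 3.0-fold lower number from compound 2 to compound 4 (0.48 log units; beyond the scatter). Changing hydroxymethyl to methoxycarbonyl gives an 8.3-fold lower number from compound 3 to compound 4 (0.92 log units; beyond the scatter), so replacing the amide at this place can move the number down as well as up. Nothing measured here accounts for the drop. Going by these compounds, whether it is specific to methoxy stays open. An ethoxycarbonyl group or a carboxylic acid at this place would test how far it extends.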